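From Compound 1 to Compound 4: A Smaller Carbonyl Substituent

The source may hold more compounds than are shown below. What is called first, only, known or untested is meant among the compounds shown, and "the series" means these compounds.

In a physicochemical assay for lipophilicity, read by HPLC, with a stated time of 90 min, tested at 100 uM (on this read-out lower numbers stand for lower lipophilicity and higher numbers for higher lipophilicity), compound 1 (`O=C(Nc1ccc(OC(F)(F)F)c(F)c1)NC1CCN(C(=O)C2(C(F)(F)F)CC2)CC1`) stands highest of three at 5.94 with compound 2 (`O=C(Nc1ccc(C(F)(F)F)c(F)c1)NC1CCN(C(=O)C2(C(F)(F)F)CC2)CC1`) nearest at 5.52 and compound 3 (`O=C(Nc1ccc(OC(F)(F)F)cc1)NC1CCN(C(=O)c2ccoc2)CC1`) furthest at 3.63 from it. Compound 4 (`CCC(=O)N1CCC(NC(=O)Nc2ccc(OC(F)(F)F)c(F)c2)CC1`), not yet measured, puts ethyl in place of 1-(trifluoromethyl)cyclopropyl on a carbonyl carbon. Among the measured compounds shown here, the one measured step (a number 0.42 log units lower from compound 1 to compound 2 (beyond the scatter)) is modest and lies on an aromatic carbon, so it does not test this place. Compound 3, which carries a different group on its carbonyl carbon and differs elsewhere too, gives 3.63 as the only loose hint of direction. A fall larger than the modest step and beyond the scatter is therefore expected (a number 1.34 log units lower from compound 1 to compound 4 (beyond the scatter)). Compound 4 is estimated at 4.6 (expected range 4 to 5.2).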

Compound 4, partition coefficient: 4
For compound 4 the middle estimate is 0.60 log units above the measured one; low and high end bracket the measured number.
By their numbers in this assay, from the lowest: compound 3; then compound 4; then compound 2; then compound 1.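

In this assay, among the compounds shown here, the change on the carbonyl carbon gives a number 1.94 log units lower from compound 1 to compound 4 (beyond the scatter), showing that this position, untested by the earlier compounds, can move the read-out by a large step. The step on the aromatic carbon was only modest, a number 0.42 log units lower from compound 1 to compound 2 (beyond the scatter). The ring and the fluorine atoms leave together, and this single step cannot be divided between them. No measurement shown gives a cause for its size.

Left open is how plain cyclopropyl or a longer chain such as butyl would read at this carbonyl carbon. Either group could help separate the contribution of the ring from that of trifluoromethyl.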